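The source may report more compounds than this note shows. Statements on the series, on what has been measured and on what is new or still open speak of the compounds shown alone.

Compound 1, `CSc1ncnc2c1c(-c1ccccc1)cn2[C@@H]1O[C@H](CO)[C@@H](O)[C@H]1O`, was tested in a functional assay on CEM-DNR-bulk cells (Homo sapiens), read by MTT assay, with a stated time of 72 h; on this read-out higher numbers stand for weaker inhibition and lower numbers for stronger inhibition. In this assay compound 1 gives > 20000 nM, which is a limit of the assay and not a number. Compound 2, `COc1ncnc2c1c(-c1ccccc1)cn2[C@@H]1O[C@H](CO)[C@@H](O)[C@H]1O`, carries a methoxy in place of methylsulfanyl on an aromatic carbon. In this assay compound 2 gives > 20000 nM, again a limit. Compound 3, `CNc1ncnc2c1c(-c1ccccc1)cn2[C@@H]1O[C@H](CO)[C@@H](O)[C@H]1O`, carries methylamino in place of methylsulfanyl on an aromatic carbon. In this assay compound 3 gives > 20000 nM, also a limit. Compound 1 thus stands only at a limit on the numbers shown. Indeed, (the limit of > 20000 nM in this assay, at which 3 of the 3 values shown sit). The steps a step that the two limits leave unreadable from compound 1 to compound 2, a step that the two limits leave unreadable from compound 1 to compound 3 and a step that the two limits leave unreadable from compound 2 to compound 3 are all left unreadable by those limits. Compound 4, `CSc1ncnc2c1c(-c1ccsc1)cn2[C@@H]1O[C@H](CO)[C@@H](O)[C@H]1O`, differs from compound 1 in another place: thiophen-3-yl in place of phenyl on an aromatic carbon. Within the data shown here, none of the measured steps changes that group, so no measured step bears on this change, and neither a size nor a direction can be read from them. Compound 4 is therefore expected to sit at the limit as well, with an estimate of 20000 nM and a range from 10000 nM to 40000 nM. The step of a number no higher from compound 1 to compound 4 (the limit leaves the size open) is likewise only an expectation.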

Compound 4, half-maximal inhibitory concentration: > 20000 nM
Compound 4 was reported as a limit; the forecaster's own chance of this, stated with the estimate: 80%; the middle value lies on the limit itself.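

Among these compounds, compound 4 gives > 20000 nM in this assay, again a limit and not a number, so no step from compound 1 to compound 4 can be read: the limit of > 20000 nM in this assay, at which 4 of the 4 values shown sit. The compounds shown leave open how strongly any of them inhibits in this assay, and whether thiophen-3-yl in place of phenyl changes that at all.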